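One Triazole Arm Fewer: Expected Tolerance in Huh-7 Cells

A few compounds are considered here, and "the series" means these few. Any claim that something is new, unique, unknown or untested is made for them only; others in the source may bear on it.

Compound 1 `COc1cc(O)c(C(=O)/C=C/c2ccc(OCc3cn(-c4ccc(F)cc4Cl)nn3)c(OCc3cn(-c4ccc(F)cc4Cl)nn3)c2)c(OC)c1`: > 100 ug/mL
Compound 2 `COc1cc(O)c(C(=O)/C=C/c2ccc(OCc3cn(-c4ccc(Cl)cc4)nn3)c(OCc3cn(-c4ccc(Cl)cc4)nn3)c2)c(OC)c1`: > 100 ug/mL

Both measured compounds were tested in an ADME assay on Huh-7 cells (Homo sapiens) for cytotoxicity, read by MTT assay, with a stated time of 72 h; a lower number here means that less compound is tolerated, a higher number that more compound is tolerated. Compound 2 gives > 100 ug/mL there, which is a limit of the assay rather than a number. Compound 1 likewise gives only a limit, > 100 ug/mL. The evidence so far comes down to the limit of > 100 ug/mL in this assay, at which 2 of the 2 values shown sit. Compound 3 `COc1cc(O)c(C(=O)/C=C/c2ccc(OC)c(OCc3cn(-c4ccc(Cl)cc4)nn3)c2)c(OC)c1` has not yet been measured. It differs from compound 2 by hydrogen in place of 1-(4-chlorophenyl)-1H-1,2,3-triazol-4-yl on a saturated chain carbon bound to an oxygen on an aromatic ring. Within the data shown here, no step between two measured compounds is available, so any expectation rests only on the two limits already seen, and neither of them shows a measurable effect on the cells. Compound 3 is expected to give 100 ug/mL, within 50 ug/mL to 200 ug/mL. The expected step of a number no higher from compound 2 to compound 3 (the limit leaves the size open) is no change beyond the usual scatter, and a further limit report is the most likely outcome.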

Compound 3, half-maximal cytotoxic concentration: > 100 ug/mL
Compound 3 ended at the assay's limit; the forecaster's own chance of this, stated with the estimate: 70%; the middle value sits exactly at the limit.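

Compound 2 and compound 3 both give only a limit rather than a number, so no step can be read between them: the limit of > 100 ug/mL in this assay, at which 3 of the 3 values shown sit.

The compounds shown leave open whether hydrogen in place of 1-(4-chlorophenyl)-1H-1,2,3-triazol-4-yl changes how much compound the cells tolerate.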